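A few compounds are considered here, and "the series" means these few. Any claim that something is new, unique, unknown or untested is made for them only; others in the source may bear on it.

Values measured in an ADME assay (Rattus norvegicus, strain Wistar Han) for pharmacokinetics; on this read-out higher numbers stand for wider distribution into tissues and lower numbers for narrower distribution:
- compound 1 `CCn1c(-c2cnc(C)nc2)nc2c(N[C@H]3CCN(C(=O)[C@H]4C[C@@H](OC)C4)C3)ncnc21`: 1.5 L/kg
- compound 2 `CCn1c(-c2cnc(C)nc2)nc2c(O[C@H]3CCN(C(=O)N4CC(OC)C4)C3)ncnc21`: 0.4 L/kg
- compound 3 `CCn1c(-c2cnc(C)nc2)nc2c(O[C@H]3CCN(C(=O)C4CCC4)C3)ncnc21`: 0.6 L/kg

Compound 1 has the highest number of the three, and its gaps to compound 3 and to compound 2 both lie beyond the usual scatter. The next compound, compound 4 `CCn1c(-c2cnc(C)nc2)nc2c(N[C@H]3CCN(C(=O)C4CCOCC4)C3)ncnc21`, has oxan-4-yl in place of 3-methoxycyclobutyl on a carbonyl carbon, while the rest of compound 1 stays the same: oxan-4-yl in place of 3-methoxycyclobutyl on a carbonyl carbon.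

Within the data shown here, no measured pair makes this exact swap. The closest evidence is one other swap on a carbonyl carbon, a 1.5-fold higher number from compound 2 to compound 3 (0.18 log units; within the scatter), and it stays within the scatter. That step is only a loose guide, since compound 2 and compound 3 also differ from compound 1 elsewhere in the structure. With so little evidence, no change beyond the scatter is expected in this assay. The expected step is small, a 1.2-fold lower number from compound 1 to compound 4 (0.06 log units; within the scatter). For compound 4 the estimated value is 1.3 L/kg, with an expected range from 0.7 L/kg to 2.4 L/kg.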

Compound 4, volume of distribution: 0.7 L/kg
Estimate against measurement, compound 4: 1.9-fold (0.27 log units) above; the range from low to high includes it.
By their numbers in this assay, from the lowest: compounds 2, 3 and 4 (each within the scatter of the next); then compound 1.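

In this assay, placing oxan-4-yl instead of 3-methoxycyclobutyl on this carbonyl carbon gives a 2.1-fold lower number from compound 1 to compound 4 (0.33 log units; beyond the scatter), a modest step, yet the only one shown on such a carbon that lies beyond the scatter. The two groups match in heavy atoms and in hydrogen-bond donors and acceptors, but the four-membered carbon ring carrying a methoxy group gives way to a six-membered ring holding the oxygen, so the read-out at this position can change even when the atoms leaving and entering are the same. Nothing available explains why the number moved.

On these data alone, what a piperidin-4-yl group, which carries an amine, or a longer chain such as n-butyl would do on this carbonyl carbon remains open. So does whether the same swap would give a similar step on the core of compound 3.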